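Flipping the double bond: from compound 2 to compound 3

The source may report more compounds than this note shows. Statements on the series, on what has been measured and on what is new or still open speak of the compounds shown alone.

Compound 1 `COc1ccc(/C(=N/O)c2cccc3ccccc23)c(OC)c1OC` gives 13100 nM in a functional assay on A549 cells (Homo sapiens) for inhibition, read by sulforhodamine B assay, with a stated time of 48 h; a higher number here means a weaker inhibitor, a lower number a stronger inhibitor.
Compound 2 `COc1ccc(/C(=C\c2ccc(F)cc2)c2cccc3ccccc23)c(OC)c1OC` gives > 20000 nM in this assay, which is a limit of the assay rather than a number.

Compound 2 therefore stands at the edge of what this assay can report, as shown by the limit of > 20000 nM in this assay, at which 1 of the 2 values shown sits, and compound 1 is the only measured compound with a real number. Compound 3 `COc1ccc(/C(=C/c2ccc(F)cc2)c2cccc3ccccc23)c(OC)c1OC` is the unmeasured partner of compound 2: the two compounds have the same atoms and bonds and differ only in configuration as drawn: 1 of 1 stereo elements differ; a double bond is drawn Z in compound 2 and E in compound 3. Among the compounds with values here, no measured pair in this set differs in only one place, so there is no measured step to lean on. Because compound 2 sits at the limit of > 20000 nM in this assay, at which 1 of the 2 values shown sits, the step of an at least 1.3-fold lower number from compound 2 to compound 3 (0.12 log units; that floor lies within the scatter) that the estimate implies is uncertain in both directions, and no change beyond the scatter is expected with any confidence. Compound 3 is estimated at 15000 nM, with a range from 3000 nM to 60000 nM.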

Compound 3, half-maximal inhibitory concentration: 18600 nM
Estimate against measurement, compound 3: 1.2-fold (0.09 log units) below; low and high end bracket the measured number.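

In this assay, compound 3 gives a real number for one arrangement of this double bond, which compound 2 could not provide. Compound 2 gives > 20000 nM, which is a limit and not a number. The step reads an at least 1.0-fold lower number from compound 2 to compound 3 (0.03 log units; that floor lies within the scatter), so moving the double bond from Z to E, with nothing entering or leaving, shows no change that stands clear of the scatter: the fact that compounds 2 and 3 differ only in the configuration as drawn

As far as these compounds go, how far compound 2 lies past its limit stays open, so the true size of the gap between the two arrangements is unknown. Also open, from the compounds shown here alone, is whether an amine or a carboxylic acid in place of the fluorine would make the arrangement of the double bond matter in this assay.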